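Benzoyl on the Ring Nitrogen: A Repeated Substitution

A few compounds are considered here, and "the series" means these few. Any claim that something is new, unique, unknown or untested is made for them only; others in the source may bear on it.

The measured compounds and their values:
compound 1, `O=C(Nc1ccccc1O)C1CCc2ccccc2N1C(=O)c1ccccc1`, 4260 nM
compound 2, `O=C(Nc1ccccc1O)C1CCc2ccccc2N1`, 3990 nM
compound 3, `O=C(Nc1cc(C(F)(F)F)cc(C(F)(F)F)c1)C1CCc2ccccc2N1`, 8190 nM

The study tested three compounds in a functional assay on ACHN cells (Homo sapiens) for cytotoxicity, read by sulforhodamine B assay, with a stated time of 72 h; a higher number here means a weaker inhibitor of growth, a lower number a stronger inhibitor of growth. Compound 2 gives 3990 nM, and compound 1, which carries the change (benzoyl in place of hydrogen on a nitrogen on an aromatic ring in a ring), gives 4260 nM. The step of a 1.1-fold higher number from compound 2 to compound 1 (0.03 log units; within the scatter) is therefore small and lies within the scatter of repeated measurements, so the two values cannot be ordered.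

Compound 3 differs from compound 2 in the group attached to the amide, and the difference between the two cores is not broken down here. In this assay compound 3 gives 8190 nM, the highest of the three numbers; its gap to compound 1 is within the scatter, while its gap to compound 2 lies beyond it.

Compound 4, `O=C(Nc1cc(C(F)(F)F)cc(C(F)(F)F)c1)C1CCc2ccccc2N1C(=O)c1ccccc1`, has not been measured. It differs from compound 3 by benzoyl in place of hydrogen on a nitrogen on an aromatic ring in a ring, the same change that separates compound 2 from compound 1, at the same place on the shared core. The expected step of a 1.1-fold higher number from compound 3 to compound 4 (0.03 log units; within the scatter) rests on the observation that the earlier instance, a 1.1-fold higher number from compound 2 to compound 1 (0.03 log units; within the scatter), changed the number hardly at all. Compound 4 is therefore estimated at 8800 nM in this assay, with a likely range from 4000 nM to 19000 nM. Within the data shown here, only one earlier example of this change exists, so the expectation is uncertain.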

Compound 4, concentration for 50% growth inhibition: 2920 nM
Compound 4: the middle estimate sits 3.0-fold (0.48 log units) above what was measured; measured number below the stated range.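

In this assay, putting benzoyl in place of hydrogen on a nitrogen on an aromatic ring in a ring produced a 2.8-fold lower number from compound 3 to compound 4 (0.45 log units; beyond the scatter), so on this core the change gave a stronger inhibitor of growth. The change therefore did not carry over with the same size from one core to the other, and its size depended on which of the two groups was attached to the amide: the same change on two cores in this assay, a 1.1-fold higher number (0.03 log units; within the scatter) from compound 2 to compound 1 and a 2.8-fold lower number (0.45 log units; beyond the scatter) from compound 3 to compound 4, 3.0-fold (0.48 log units) apart, beyond the scatter of two such steps

This comparison rests on just two matched pairs, and it shows neither why the two steps differ nor which of them, if either, is typical of the series; a single pair on each core also cannot separate a general trend from a feature of that one core.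

Among these compounds, it remains open whether a smaller acyl group such as acetyl on the same nitrogen, or a benzoyl ring carrying a methoxy group or a chlorine, would give a step like the one seen with compound 4 or the one seen with compound 1. As far as these compounds go, it is equally open how the change would behave with other groups on the amide, such as a phenyl ring bearing a single trifluoromethyl or an amine.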